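The compounds below may be only part of what the source reports. "The series", "measured", "known", "first", "only" and "open" are said of these compounds alone.

Four amide compounds share a common backbone and differ at two spots: the group carried on one end of the amide and the group attached para to a large group on the other aromatic ring. Compound 1 has the structure `O=C(Nc1cc(C(F)(F)F)cc(C(F)(F)F)c1)c1ccc(Sc2ccc(O)cc2)cc1`. Compound 2, with the structure `O=C(Nc1cccc(S(F)(F)(F)(F)F)c1)c1ccc(Sc2ccc(O)cc2)cc1`, carries a different group on the amide end; the difference between the two cores is not broken down here. Compound 3 has the structure `O=C(Nc1cc(C(F)(F)F)cc(C(F)(F)F)c1)c1ccc(S(=O)(=O)c2ccc(O)cc2)cc1`, and compound 4, not yet measured, has the structure `O=C(Nc1cccc(S(F)(F)(F)(F)F)c1)c1ccc(S(=O)(=O)c2ccc(O)cc2)cc1`.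

In a functional assay on CWR22R cells (Homo sapiens) for antiproliferative activity, read by fluorescence and propidium iodide staining, with a stated time of 96 h (a lower number here means a stronger inhibitor, a higher number a weaker inhibitor), compound 1 gives 3350 nM, and compound 2 gives 2940 nM; the two values lie within the scatter of each other. In this assay compound 3 gives 6440 nM. The change from compound 1 to compound 3 is (4-hydroxyphenyl)sulfonyl in place of (4-hydroxyphenyl)sulfanyl on an aromatic carbon, and it produced a 1.9-fold higher number from compound 1 to compound 3 (0.28 log units; within the scatter).

Compound 4 is related to compound 2 by the same change, ((4-hydroxyphenyl)sulfonyl in place of (4-hydroxyphenyl)sulfanyl on an aromatic carbon), made at the same kind of place. Among the measured compounds shown here, the step from compound 2 to compound 4 in this assay is therefore expected to be a 1.9-fold higher number from compound 2 to compound 4 (0.27 log units; within the scatter), resting on the single earlier step of a 1.9-fold higher number from compound 1 to compound 3 (0.28 log units; within the scatter), which was within the scatter, so the expectation carries considerable uncertainty. For compound 4 in this assay the estimated value is 5500 nM, with an expected range from 2800 nM to 11000 nM.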

Compound 4, half-maximal inhibitory concentration: 5660 nM
For compound 4 the middle estimate is 1.0-fold (0.01 log units) below the measured one, within the range that was stated.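

In this assay, putting (4-hydroxyphenyl)sulfonyl in place of (4-hydroxyphenyl)sulfanyl gives a 1.9-fold higher number from compound 2 to compound 4 (0.28 log units; within the scatter), and this step matches the one seen earlier on the core of compound 1: the same change on two cores in this assay, a 1.9-fold higher number (0.28 log units; within the scatter) from compound 1 to compound 3 and a 1.9-fold higher number (0.28 log units; within the scatter) from compound 2 to compound 4, 1.0-fold (0.00 log units) apart, within the scatter of two such steps For these two cores, then, the size of the step carried over from one to the other, and the group on the amide end made no visible difference to it. This does not show that the change has a real effect on the cells, since each step on its own lies within the scatter, and two pairs of compounds cannot establish a rule for the whole series or explain why the steps agree.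

The compounds shown leave open whether the step would hold on a core with a different amide end, such as one carrying a nitrile in place of the fluorinated groups of compound 1 and compound 2. They also leave open how the numbers would look with a plain oxygen or a methylene as the link in place of the sulfur, or with an amine or a carboxylic acid in place of the hydroxyl on the 4-hydroxyphenyl ring.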